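From chloro to trifluoromethyl at the assay's limit

A few compounds are considered here, and "the series" means these few. Any claim that something is new, unique, unknown or untested is made for them only; others in the source may bear on it.

In a functional assay on HUVEC cells (Homo sapiens) for antiproliferative activity, read by MTT assay, with a stated time of 24 h (a higher number here means a weaker inhibitor, a lower number a stronger inhibitor), compound 1 `COc1cc(OC)c(-c2coc3cc(OCc4ccccc4)ccc3c2=O)cc1OC` gives 9750 nM. Compound 2 `COc1cc(OC)c(-c2coc3cc(OCc4cccc(Cl)c4)ccc3c2=O)cc1OC` gives only a limit, not a number: > 10000 nM. Compound 3 `COc1cc(OC)c(-c2coc3cc(OCc4cccc(C(F)(F)F)c4)ccc3c2=O)cc1OC` carries trifluoromethyl in place of chloro on an aromatic carbon. Within the data shown here, one measured step bears on this change: chloro in place of hydrogen gives an at least 1.0-fold higher number from compound 1 to compound 2 (0.01 log units; that floor lies within the scatter). That small floor offers no basis for predicting a clear shift in this assay. Among the measured compounds shown here, the expected change is a step that the limit leaves unreadable from compound 2 to compound 3, with no step expected beyond the scatter. The estimate for compound 3 is 11000 nM, within an expected range of 5000 nM to 25000 nM.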

Compound 3, half-maximal inhibitory concentration: > 10000 nM
Compound 3 was reported as a limit; the forecaster's own chance of this, stated with the estimate: 60%; the middle value is on the limit's open side.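

In this assay, compound 3 joins compound 2 at a limit rather than a number, so trifluoromethyl on this aromatic carbon, like chloro, yields no exact value. Trifluoromethyl in place of hydrogen gives an at least 1.0-fold higher number from compound 1 to compound 3 (0.01 log units; that floor lies within the scatter) and so supports no claim of a clear shift. The step between the two substituted compounds cannot be read, because both values are limits: the limit of > 10000 nM in this assay, at which 2 of the 3 values shown sit.

As far as these compounds go, how far compound 2 and compound 3 lie past that limit stays open. So does whether an amine or a carboxylic acid on this aromatic carbon would give a measurable value.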